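This account rests on a few compounds, and the source may have more. Where it says the series, first, only, none or still open, it means among the compounds named here.

Measured so far in a functional assay on MCF7 cells (Homo sapiens) for inhibition, read by MTT assay, with a stated time of 24 h; a higher number here means a weaker inhibitor, a lower number a stronger inhibitor:
compound 1 `CCOC(=O)C1=Cc2ccccc2OC1(OCc1cn(CC(=O)Nc2ccc(OC)cc2)nn1)C(F)(F)F`: 28100 nM
compound 2 `CCOC(=O)C1=Cc2ccccc2OC1(OCc1cn(-c2ccc(F)c([N+](=O)[O-])c2)nn1)C(F)(F)F`: 16200 nM

Compound 2 stands at one end of the two numbers, separated from compound 1 only by a 1.7-fold lower number from compound 1 to compound 2 (0.24 log units; within the scatter). Compound 3 `CCOC(=O)C1=Cc2ccccc2OC1(OCc1cn(-c2ccc(F)c(Cl)c2)nn1)C(F)(F)F` differs from compound 2 by chloro in place of nitro on an aromatic carbon. Within the data shown here, no measured step touches this position: the single step between the measured compounds exchanges the whole group on the aromatic nitrogen, and even that exchange stays within the scatter. With nothing pointing either way, the step from compound 2 to compound 3 is expected to be a 1.0-fold lower number from compound 2 to compound 3 (0.01 log units; within the scatter). Compound 3 is therefore estimated at 16000 nM, with a range from 5000 nM to 50000 nM.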

Compound 3, half-maximal inhibitory concentration: 25300 nM
Beside the measured number, compound 3's estimate is 1.6-fold (0.20 log units) below it; low and high end bracket the measured number.
By their numbers in this assay, from the lowest: compounds 2, 3 and 1 (each within the scatter of the next).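

In this assay the first step read at this position gives a 1.6-fold higher number from compound 2 to compound 3 (0.19 log units; within the scatter) when nitro leaves and chloro enters, and the aromatic carbon ortho to the fluoro group takes this exchange of 3 heavy atoms for 1 without leaving the scatter. The exchange on the aromatic nitrogen, now read with 3-chloro-4-fluorophenyl, gives a 1.1-fold lower number from compound 1 to compound 3 (0.05 log units; within the scatter) and also stays within the scatter. No available evidence bears on either step. As far as these compounds go, whether an amine or a carboxylic acid at this aromatic carbon would move the number beyond the scatter remains open.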